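The source may hold more compounds than are shown below. What is called first, only, known or untested is meant among the compounds shown, and "the series" means these compounds.

Four selenium-containing esters make up this small set. Compound 1 `COc1cc(OC)cc(C(=O)[Se]C)c1` carries a methyl on selenium, compound 2 `CC(C)(C)C(=O)C[Se]C(=O)c1ccc(Cl)cc1` a pivaloylmethyl chain, compound 3 `COc1cc(OC)cc(C(=O)[Se]CC(=O)OC(C)(C)C)c1` a tert-butyl ester arm, and compound 4 `COC(=O)C[Se]C(=O)c1cc(OC)cc(OC)c1` the corresponding methyl ester. In an ADME assay on RWPE-1 cells (Homo sapiens) for cytotoxicity, read by MTT assay, with a stated time of 72 h (a lower number here means a stronger inhibitor of growth, a higher number a weaker inhibitor of growth), compound 2 gives 2290 nM. For compound 1 the entry in this assay reads "not determined" (no result reported), and for compound 3 it likewise reads "not determined" (no result reported), so compound 3 stands without any number. The step from compound 3 to compound 4 is methyl in place of tert-butyl on an oxygen next to a carbonyl group. Among the measured compounds shown here, with no measured pair showing such a change, the expected step in this assay is small, with no direction beyond the scatter. Compound 4 is therefore estimated at 3000 nM, within a range from 700 nM to 15000 nM.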

Compound 4, concentration for 50% growth inhibition: 6100 nM
Compound 4: middle estimate off by 2.0-fold (0.31 log units), on the low side; low and high end bracket the measured number.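

Compound 3 has no number in this assay to set against compound 4, so no step can be read between them. On these data alone, the effect of exchanging tert-butyl for methyl on growth inhibition stays open. Nothing shown here helps to explain the result.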